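The source may hold more compounds than are shown below. What is called first, only, known or untested is meant among the compounds shown, and "the series" means these compounds.

Measured in a functional assay on HepG2 cells (Homo sapiens) for antiproliferative activity, read by MTT assay, with a stated time of 72 h; on this read-out lower numbers stand for stronger inhibition and higher numbers for weaker inhibition:
compound 1 `Cn1nc(-c2nnc(-c3ccccc3Cl)o2)c2ccccc21` gives 45000 nM
compound 2 `Cn1nc(-c2nnc(-c3ccccc3Br)o2)c2ccccc21` gives 22300 nM
compound 3 `Cn1nc(-c2nnc(-c3ccc(Cl)cc3)o2)c2ccccc21` gives 42000 nM

The three values lie close together and every step among them falls within the scatter. Compound 4 `Cn1nc(-c2nnc(-c3ccc(Br)cc3)o2)c2ccccc21` is not yet measured. It differs from compound 3 by bromo in place of chloro on an aromatic carbon. The same kind of change is already covered by bromo in place of chloro on an aromatic carbon, which gave a 2.0-fold lower number from compound 1 to compound 2 (0.30 log units; within the scatter). The two cases are the same kind of change, not the same: in compound 1 the exchanged halogen sits ortho to a large group, in compound 3 para to a large group. The two cores differ by 4-chlorophenyl in place of 2-chlorophenyl on an aromatic carbon. The expectation for compound 4 is a step of a 1.7-fold lower number from compound 3 to compound 4 (0.23 log units; within the scatter), resting on a 2.0-fold lower number from compound 1 to compound 2 (0.30 log units; within the scatter), which stayed within the scatter, so the change is expected to move the number little beyond it. Compound 4 is therefore estimated at 25000 nM in this assay, with a likely range from 10000 nM to 60000 nM.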

Compound 4, half-maximal inhibitory concentration: 40000 nM
For compound 4 the middle estimate is 1.6-fold (0.20 log units) below the measured one, within the range that was stated.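

In this assay, bromo in place of chloro was tried on two cores, and the two steps do not differ: the same change on two cores in this assay, a 2.0-fold lower number (0.30 log units; within the scatter) from compound 1 to compound 2 and a 1.1-fold lower number (0.02 log units; within the scatter) from compound 3 to compound 4, 1.9-fold (0.28 log units) apart, within the scatter of two such steps

The new step is a 1.1-fold lower number from compound 3 to compound 4 (0.02 log units; within the scatter), so the change carries from the core of compound 1 to the core of compound 3 without a detectable difference, but neither step shows a real effect of the change on its core. The steps that accompany 4-bromophenyl, a 1.8-fold higher number from compound 2 to compound 4 (0.25 log units; within the scatter) and a 1.1-fold lower number from compound 1 to compound 4 (0.05 log units; within the scatter), also stay within the scatter, so the four compounds favour neither halogen nor either placement, and two cores give no general rule on carrying the change further.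

From the compounds shown here alone, all four compounds carry a single chloro or bromo on the phenyl ring, so it remains open whether any group there can move the number beyond the scatter. An amine or a carboxylic acid in place of the halogen, or a longer chain in place of the methyl group, would test this.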